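Heteroaryl amide swaps on a bis(trifluoromethyl)anilide core

The source may hold more compounds than are shown below. What is called first, only, known or untested is meant among the compounds shown, and "the series" means these compounds.

Measured so far:
compound 1, `Cn1nnc(O)c1C(=O)Nc1cc(C(F)(F)F)cc(C(F)(F)F)c1`: > 100000 nM
compound 2, `Nc1nonc1C(=O)Nc1cc(C(F)(F)F)cc(C(F)(F)F)c1`: > 100000 nM

Of the compounds shown here, two have been tested in an assay on isolated protein for inhibition of mitogen-activated protein kinase kinase kinase 14 (Homo sapiens), read by ADP-Glo, with a stated time of 60 min, in the presence of a further agent that is not named here; a higher number here means a weaker inhibitor, a lower number a stronger inhibitor. Compound 1 `Cn1nnc(O)c1C(=O)Nc1cc(C(F)(F)F)cc(C(F)(F)F)c1` gives > 100000 nM in this assay, which is a limit of the assay and not a number. Compound 2 `Nc1nonc1C(=O)Nc1cc(C(F)(F)F)cc(C(F)(F)F)c1` likewise gives > 100000 nM in this assay, again a limit rather than a number. Within the data shown here, the single step between them, a step that the two limits leave unreadable from compound 1 to compound 2, cannot be read, as the limit of > 100000 nM in this assay, at which 2 of the 2 values shown sit, shows. Compound 2 therefore stands only at the limit, with no measured value that would place it above or below compound 1.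

Compound 3 `Cc1c(C(=O)Nc2cc(C(F)(F)F)cc(C(F)(F)F)c2)c(O)nn1C` has not yet been measured. It differs from compound 2 by 3-hydroxy-1,5-dimethyl-1H-pyrazol-4-yl in place of 4-amino-1,2,5-oxadiazol-3-yl on a carbonyl carbon. Among the measured compounds shown here, no measured step bears on this change: the only step available is unreadable, so neither a direction nor a size can be taken from it, and the expectation rests on the limit alone. Compound 3 is expected to give about 100000 nM in this assay, somewhere between 30000 nM and 300000 nM, most probably reported again as a limit. The step this estimate implies is a number no higher from compound 2 to compound 3 (the limit leaves the size open).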

Compound 3, half-maximal inhibitory concentration: > 100000 nM
Compound 3 was reported as a limit (the forecaster's own chance of this, stated with the estimate: 85%); the middle value sits exactly at the limit.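

Among these compounds, no step among compound 1, compound 2 and compound 3 can be read in this assay, because all three give a limit of the assay and not a number: the limit of > 100000 nM in this assay, at which 3 of the 3 values shown sit. The compounds shown leave open whether these three groups on the carbonyl carbon differ at all in their inhibition, and what group on the shared core would give a measurable value.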